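The source may report more compounds than this note shows. Statements on the series, on what has been measured and on what is new or still open speak of the compounds shown alone.

Measured compounds:
compound 1 `COc1ccc(NC(=O)CN2CCN(S(=O)(=O)c3ccc(F)cc3)CC2)cc1`: 29600 nM
compound 2 `O=C(CN1CCN(S(=O)(=O)c2cccnc2)CC1)Nc1ccccc1F`: 49600 nM

In an in vitro assay on HEK ts201 cells for negative allosteric modulation of Neuronal acetylcholine receptor; alpha3/beta4 (Homo sapiens), read by fluorescence and calcium flux, with a stated time of 1.5 s (on this read-out lower numbers stand for stronger inhibition and higher numbers for weaker inhibition), compound 2 gives 49600 nM, and compound 1 gives 29600 nM, a number that lies within the scatter of it, so neither of the two stands apart from the other. The two compounds differ in two places, and their values show only that both are weak inhibitors in this assay. Compound 3 `COc1ccc(S(=O)(=O)N2CCN(CC(=O)Nc3ccccc3F)CC2)cc1` keeps the amide side of compound 2 and carries 4-methoxyphenyl in place of pyridin-3-yl on a sulfonyl sulfur, the same group that compound 1 bears on its sulfonyl sulfur. For the measured compounds named here, no single-point step between measured compounds is available, and compound 1 and compound 2 sit within the scatter of each other, so no step beyond the scatter is expected in this assay: the estimated step of a 1.4-fold lower number from compound 2 to compound 3 (0.15 log units; within the scatter) is close to none. Compound 3 is expected to give about 35000 nM, with a range from 12000 nM to 100000 nM.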

Compound 3, half-maximal inhibitory concentration: 15400 nM
Compound 3: the middle estimate sits 2.3-fold (0.36 log units) above what was measured; the measured number falls inside the stated range.
By their numbers in this assay, from the lowest: compounds 3, 1 and 2 (each within the scatter of the next, the first and the last beyond it).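

In this assay, the group on the sulfonyl sulfur is shown for the first time to move the number on its own: with the amide side held fixed, 4-methoxyphenyl in place of pyridin-3-yl gives a modest change (a 3.2-fold lower number from compound 2 to compound 3 (0.51 log units; beyond the scatter)), the only single-place step available. Even so, compound 3 (15400 nM) remains a weak inhibitor in this assay, so the change improves on compound 2 without altering that overall picture. Nothing available here bears on why the step arises.

As far as these compounds go, it remains open whether the step depends on the methoxy group or on the loss of the ring nitrogen, a distinction that plain phenyl or 4-chlorophenyl on the sulfonyl sulfur could help draw. From the compounds shown here alone, it is also open whether the same change would give a similar step with a different amide side, such as that of compound 1.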